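Chain extension from compound 2 to compound 3

The compounds below may be only part of what the source reports. "The series", "measured", "known", "first", "only" and "open" are said of these compounds alone.

In a functional assay on HT-29 cells (Homo sapiens) for inhibition, read by sulforhodamine B assay, with a stated time of 72 h (a lower number here means a stronger inhibitor, a higher number a weaker inhibitor), compound 1 `COc1cc2c(Nc3ccc(F)c(Cl)c3)ncnc2cc1OCCCn1ccnc1[N+](=O)[O-]` gives 2060 nM and compound 2 `COc1cc2c(Nc3cccc(Br)c3)ncnc2cc1OCCCn1ccnc1[N+](=O)[O-]` gives 2820 nM as its number, so the two lie within the scatter of each other. Compound 3 `COc1cc2c(Nc3cccc(Br)c3)ncnc2cc1OCCCCCn1ccnc1[N+](=O)[O-]` carries one change on the saturated chain: 2-(2-nitro-1H-imidazol-1-yl)ethyl in place of 2-nitro-1H-imidazol-1-yl on a saturated chain carbon, three bonds along the chain from an oxygen on an aromatic ring is the whole difference. Within the data shown here, the sole measured step, a 1.4-fold higher number from compound 1 to compound 2 (0.14 log units; within the scatter), concerns the group on the nitrogen, and no measured step covers the chain. No shift beyond the scatter is therefore expected, and the expected step is a 1.1-fold lower number from compound 2 to compound 3 (0.05 log units; within the scatter) in this assay here. Compound 3 is estimated at 2500 nM with 1000 nM to 6500 nM as the expected range.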

Compound 3, half-maximal inhibitory concentration: 2540 nM
Beside the measured number, compound 3's estimate is 1.0-fold (0.01 log units) below it; the range from low to high includes it.
By their numbers in this assay, from the lowest: compounds 1, 3 and 2 (each within the scatter of the next).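

Moving the nitroimidazole further out on the saturated chain, with 2-(2-nitro-1H-imidazol-1-yl)ethyl in place of 2-nitro-1H-imidazol-1-yl, gives a 1.1-fold lower number from compound 2 to compound 3 (0.05 log units; within the scatter) in this assay and is the first reading at this position. In this series, then, the added chain length does not move the number beyond the scatter on the 3-bromophenyl compounds. Nothing available explains this result.

Open, going by these compounds, is whether a still longer chain, or an amine in place of the 2-nitro-1H-imidazol-1-yl group, would shift the number. Also open, on these data alone, is whether the chain change reads the same with 3-chloro-4-fluorophenyl on the nitrogen.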